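Replacing the oxazolidinone sulfanyl chain with a branched aminopropyl

The compounds below may be only part of what the source reports. "The series", "measured", "known", "first", "only" and "open" are said of these compounds alone.

Compound 1 `CC(C)c1n[nH]c2c(NCc3ccc(-c4ccccn4)cc3)nc(SCC3CNC(=O)O3)nc12` was assessed in a functional assay on HT cells (Homo sapiens) for antiproliferative activity, read by fluorescence, with a stated time of 72 h (a higher number here means a weaker inhibitor of growth, a lower number a stronger inhibitor of growth), where compound 1 gives 80 nM. Two close relatives share its core and differ only in the chain on the sulfur: compound 2 `CNCCSc1nc(NCc2ccc(-c3ccccn3)cc2)c2[nH]nc(C(C)C)c2n1` gives 56 nM, and compound 3 `CC(C)c1n[nH]c2c(NCc3ccc(-c4ccccn4)cc3)nc(SCCCN)nc12` gives 120 nM. Going by the values given here, compound 1 sits between them; the change a 1.4-fold lower number from compound 1 to compound 2 (0.15 log units; within the scatter) and the change a 1.5-fold higher number from compound 1 to compound 3 (0.18 log units; within the scatter) are both within the scatter, while the change a 2.1-fold higher number from compound 2 to compound 3 (0.33 log units; beyond the scatter) is the only step here that reaches beyond it.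

Compound 4 `CC(C)c1n[nH]c2c(NCc3ccc(-c4ccccn4)cc3)nc(SCC(C)(C)N)nc12` differs from compound 1 in one place: 1-amino-1-methylethyl in place of 2-oxo-1,3-oxazolidin-5-yl on a saturated chain carbon bound to a sulfur. The steps from compound 1 to compound 2 and to compound 3 both swap the same ring for an open amine-bearing chain, and neither moved the number beyond the scatter, so the most relevant precedent points to little or no change. Compound 3 carries the closest open chain to that of compound 4, and its value is within the scatter of compound 1.

The expectation for compound 4 in this assay is therefore a number close to that of compound 1, estimated at 100 nM with a range of 50 nM to 220 nM, and the expected step of a 1.3-fold higher number from compound 1 to compound 4 (0.10 log units; within the scatter) is within the scatter.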

Compound 4, concentration for 50% growth inhibition: 85 nM
The estimate for compound 4 lay 1.2-fold (0.07 log units) above the measured number, within the range that was stated.
By their numbers in this assay, from the lowest: compounds 2, 1, 4 and 3 (each within the scatter of the next, the first and the last beyond it).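

In this assay, the new chain gives a 1.1-fold higher number from compound 1 to compound 4 (0.03 log units; within the scatter), so 1-amino-1-methylethyl on a saturated chain carbon bound to a sulfur reads the same as the 2-oxo-1,3-oxazolidin-5-yl it replaces. Going by these compounds alone, the two open-chain comparisons add to this: a 1.4-fold lower number from compound 3 to compound 4 (0.15 log units; within the scatter) and a 1.5-fold higher number from compound 2 to compound 4 (0.18 log units; within the scatter), so compound 4 stands within the scatter of all three earlier compounds, and adding this third amine-bearing chain opens no new gap at this position; the only gap beyond the scatter remains the one between compound 2 and compound 3. No measurement offered here accounts for why these different groups give such similar numbers.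

The compounds shown leave open whether the same level of growth inhibition would hold if the amine on this chain gave way to a hydroxyl or a carboxylic acid, since every open chain here carries an amine. They also leave open how a longer chain, or a larger group such as a phenyl ring, on the sulfur would read in this assay.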